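From piperidin-1-yl to dimethylamino: solubility working notes

A few compounds are considered here, and "the series" means these few. Any claim that something is new, unique, unknown or untested is made for them only; others in the source may bear on it.

Of the compounds shown here, three have been measured in a physicochemical assay for solubility, read by nephelometry; on this read-out lower numbers stand for lower solubility and higher numbers for higher solubility. Compound 1 `CC1(C)C(=O)N(c2ccc(SC(F)(F)F)cc2)C(=O)N1Cc1ccncc1` gives < 0.02 ug/mL, which is a limit and not a number. Compound 2 `CC1(C)C(=O)N(c2ccc(SC(F)(F)F)cc2)C(=O)N1Cc1ccnc(N2CCCCC2)c1` gives < 0.024 ug/mL, which is also only a limit. Among the measured compounds shown here, compound 3 `CN1CCN(c2cc(CN3C(=O)N(c4ccc(SC(F)(F)F)cc4)C(=O)C3(C)C)ccn2)CC1` gives 0.159 ug/mL, the only true number so far.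

The next step leads to compound 4 `CN(C)c1cc(CN2C(=O)N(c3ccc(SC(F)(F)F)cc3)C(=O)C2(C)C)ccn1`, with this change: dimethylamino in place of piperidin-1-yl on an aromatic carbon. The measured steps that bear on it are all substitutions on an aromatic carbon. Piperidin-1-yl in place of hydrogen gave a step that the two limits leave unreadable from compound 1 to compound 2. 4-Methylpiperazin-1-yl in place of hydrogen gave an at least 7.9-fold higher number from compound 1 to compound 3 (0.90 log units; beyond the scatter). 4-Methylpiperazin-1-yl in place of piperidin-1-yl gave an at least 6.6-fold higher number from compound 2 to compound 3 (0.82 log units; beyond the scatter). Dimethylamino is a different group from 4-methylpiperazin-1-yl, so only a small part of an at least 6.6-fold higher number from compound 2 to compound 3 (0.82 log units; beyond the scatter) is expected to carry over. In this assay, the expected result is a small upward change, an at least 1.2-fold higher number from compound 2 to compound 4 (0.09 log units; that floor lies within the scatter), and another limit would be no surprise. For compound 4 the estimate is 0.03 ug/mL, with an expected range of 0.012 ug/mL to 0.12 ug/mL.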

Compound 4, solubility: < 0.022 ug/mL
Compound 4 gave a limit, no number; the forecaster's own chance of this, stated with the estimate: 55%; middle value at least 1.3-fold (0.13 log units) from the limit.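

Dimethylamino next to the ring nitrogen does not reproduce the result of 4-methylpiperazin-1-yl in this assay, giving an at least 7.2-fold lower number from compound 3 to compound 4 (0.85 log units; beyond the scatter). Among the three amino groups shown on this carbon, therefore, only 4-methylpiperazin-1-yl in compound 3 gives a true number, and the smaller open-chain dimethylamino group joins piperidin-1-yl and hydrogen in yielding only a limit. Compound 4 gives a limit and not a number: the limit of < 0.022 ug/mL in this assay, at which 1 of the 4 values shown sits. The steps linking compound 4 with compound 1 and compound 2 cannot be read, all three values being limits.

Any order among hydrogen, piperidin-1-yl and dimethylamino therefore stays open. Piperazin-1-yl without the methyl, or morpholin-4-yl, on the same carbon would show how much of the group in compound 3 its number depends on.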